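A few compounds are considered here, and "the series" means these few. Any claim that something is new, unique, unknown or untested is made for them only; others in the source may bear on it.

Three compounds have been measured in an ADME assay on PC-3 cells (Homo sapiens) for cytotoxicity, read by sulforhodamine B assay, with a stated time of 48 h, tested at 10 uM; a higher number here means more inhibition at the concentration tested (going by the name of the read-out), a lower number less inhibition:
compound 1 `COc1nc2ccc(Br)cc2cc1C(c1ccccc1)n1cc(-c2ccccc2F)nn1`, giving 13.4%
compound 2 `CCCCCCCCc1cn(C(c2ccccc2)c2cc3cc(Br)ccc3nc2OC)nn1`, giving 2.27%
compound 3 `CCOC(=O)c1cn(C(c2ccccc2)c2cc3cc(Br)ccc3nc2OC)nn1`, giving 16.1%

Among these three numbers compound 1 stands second highest. Its nearest neighbour is compound 3, and the step of a number 2.7 percentage points higher from compound 1 to compound 3 (within the scatter) lies within the scatter, so no order between the two can be read. Its furthest is compound 2, and a number 11.1 percentage points lower from compound 1 to compound 2 (beyond the scatter) lies beyond the scatter. The remaining step, a number 13.8 percentage points higher from compound 2 to compound 3 (beyond the scatter), also lies beyond the scatter.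

The unmeasured compound 4 `COc1nc2ccc(Br)cc2cc1C(c1ccccc1)n1cc(CCO)nn1` differs from compound 1 in one place: 2-hydroxyethyl in place of 2-fluorophenyl on an aromatic carbon. The measured steps that bear on this are the two that likewise start from compound 1 and exchange the 2-fluorophenyl group on that aromatic carbon: a number 11.1 percentage points lower from compound 1 to compound 2 (beyond the scatter), a modest downward step, and a number 2.7 percentage points higher from compound 1 to compound 3 (within the scatter), a step within the scatter. Neither earlier replacement resembles a short 2-hydroxyethyl chain, so the guidance is loose. Compound 4 is expected to sit near compound 1, with the estimated step of a number 3.4 percentage points lower from compound 1 to compound 4 (within the scatter) staying within the scatter, leaning if anything slightly downward. Compound 4 is therefore estimated at 10%, with a range from 0% to 22%.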

Compound 4, a percentage reported as inhibition, at one concentration (the size of the read-out at that concentration, not a potency): 15.5%
Compound 4: middle estimate off by 5.5 percentage points, on the low side, within the range that was stated.
By their numbers in this assay, from the lowest: compound 2; then compounds 1, 4 and 3 (each within the scatter of the next).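

In this assay, the position on the five-membered aromatic ring takes a 2-hydroxyethyl group, with no ring and far fewer heavy atoms than 2-fluorophenyl, and the number stays put: the change gives a number 2.1 percentage points higher from compound 1 to compound 4 (within the scatter) and the exchange for ethoxycarbonyl gives a number 0.6 percentage points lower from compound 3 to compound 4 (within the scatter) so three unlike groups at this place cannot be told apart. Octyl alone stands apart from this group of three, and the new comparison a number 13.2 percentage points higher from compound 2 to compound 4 (beyond the scatter) shows that, on the same chain, hydroxy in place of hexyl, two bonds along the chain from an aromatic carbon, brings the number back to the level of the others. The data offer no explanation of why octyl behaves differently from the other three groups. Open, going by these compounds, is whether a butyl or hexyl chain would already give the low number of octyl, and whether a 2-aminoethyl group or a carboxylic acid at this position would fall outside the group of three. Also open, on these data alone, is how these compounds would separate at other concentrations, since one concentration gives no potency, and what the shared core contributes to these small numbers.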